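This account rests on a few compounds, and the source may have more. Where it says the series, first, only, none or still open, it means among the compounds named here.

Measured compounds and their numbers in the cell assay:

compound 1, `O=C1C=C[C@@H](OCc2ccccc2)[C@@H]([C@@H](COC(=O)/C=C/c2ccccc2)OCc2ccccc2)O1`, gives 9510 nM
compound 2, `COc1ccc(/C=C/C(=O)OC[C@@H](OCc2ccccc2)[C@H]2OC(=O)C=C[C@H]2OCc2ccccc2)cc1`, gives 1080 nM
compound 3, `CC(=O)O[C@@H]1C=CC(=O)O[C@@H]1[C@@H](COC(=O)/C=C/c1ccccc1)OC(C)=O`, gives 210 nM

These numbers come from a functional assay on HeLa cells (Homo sapiens) for antiproliferative activity, read by MTT assay, with a stated time of 6 days; on this read-out higher numbers stand for weaker inhibition and lower numbers for stronger inhibition. Compound 2 differs from compound 1 in one place only, (methoxy in place of hydrogen on an aromatic carbon), and that single change gave an 8.8-fold lower number from compound 1 to compound 2 (0.94 log units; beyond the scatter). Compound 3 carries a different core from compound 1 and compound 2; the difference between the two cores is not broken down here. Compound 3 has the lowest number of the three, and its distances to compound 2 and to compound 1 both lie beyond the usual scatter.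

Compound 4, `COc1ccc(/C=C/C(=O)OC[C@@H](OC(C)=O)[C@H]2OC(=O)C=C[C@H]2OC(C)=O)cc1`, has not yet been measured. It stands to compound 3 as compound 2 stands to compound 1: the change is methoxy in place of hydrogen on an aromatic carbon, at the same kind of place as before, on an aromatic carbon of a six-membered aromatic ring of carbon only, para to a large group. Because the same change produced an 8.8-fold lower number from compound 1 to compound 2 (0.94 log units; beyond the scatter), a step in the same direction is expected from compound 3 to compound 4, though a somewhat smaller one, since the two cores differ and the earlier step is the only one to go on. The expected step is a 4.7-fold lower number from compound 3 to compound 4 (0.67 log units; beyond the scatter). Compound 4 is therefore estimated at 45 nM in this assay, most likely between 15 nM and 150 nM.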

Compound 4, half-maximal inhibitory concentration: 5930 nM
Compound 4: the middle estimate sits 130-fold (2.12 log units) below what was measured, outside the stated range (above it).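

In this assay, the move from phenyl to 4-methoxyphenyl gave a 28-fold higher number from compound 3 to compound 4 (1.45 log units; beyond the scatter), the opposite of what the same change did on the core of compound 1. The effect of this change therefore depends on the core it sits on, and the gap between the two results is too large to put down to ordinary variation between repeat measurements: the same change on two cores in this assay, an 8.8-fold lower number (0.94 log units; beyond the scatter) from compound 1 to compound 2 and a 28-fold higher number (1.45 log units; beyond the scatter) from compound 3 to compound 4, 250-fold (2.40 log units) apart, beyond the scatter of two such steps. This does not show which part of the difference between the two cores matters, and with one pair on each core, it cannot say how either core would respond to other changes or how a third core would respond to this one.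

Still open, from the compounds shown here alone, is whether an amine or a hydroxyl group at the same place on the aromatic ring would also pull the two cores in opposite directions, or whether that split is particular to methoxy. A longer chain there, such as ethoxy, raises the same question, and comparing it on both cores would show whether the size of each step holds up as the group grows.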